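The source may report more compounds than this note shows. Statements on the series, on what has been measured and on what is new or still open speak of the compounds shown alone.

Among the measured compounds shown here, in a functional assay on A549 cells (Homo sapiens) for cytotoxicity, read by MTT assay, with a stated time of 24 h (on this read-out higher numbers stand for weaker inhibition and lower numbers for stronger inhibition), three compounds sharing one core have numbers so far. Compound 1 `O=C(O)c1ccc(CN2C(=O)S/C(=C\c3ccncc3)C2=O)cc1` gives 72000 nM, compound 2 `COc1cccc(/C=C2\SC(=O)N(Cc3ccc(C(=O)O)cc3)C2=O)c1` gives 55000 nM, and compound 3 `COc1cc(/C=C2\SC(=O)N(Cc3ccc(C(=O)O)cc3)C2=O)cc(OC)c1OC` gives 36000 nM. Compound 2 therefore stands within the scatter of both of the other compounds, and its number alone marks out no clear place among them.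

Compound 4 `COc1ccc(/C=C2\SC(=O)N(Cc3ccc(C(=O)O)cc3)C2=O)cc1` has the same atoms as compound 2, joined differently: 4-methoxyphenyl in place of 3-methoxyphenyl on a double-bonded chain carbon bound to a double-bonded ring carbon. It carries 4-methoxyphenyl in place of 3-methoxyphenyl on a double-bonded chain carbon bound to a double-bonded ring carbon.

For the measured compounds named here, no measured step makes this exact exchange. The closest evidence is the change at the same place, where 3-methoxyphenyl replaces pyridin-4-yl, giving a 1.3-fold lower number from compound 1 to compound 2 (0.12 log units; within the scatter). That step stays within the scatter, and compound 3, with 36000 nM, also stays within the scatter of compound 2. The data therefore give no reason to expect a real shift in either direction. The estimated step is a 1.1-fold lower number from compound 2 to compound 4 (0.04 log units; within the scatter), which is expected to stay within the scatter. For compound 4 the estimated value is 50000 nM, with an expected range from 25000 nM to 100000 nM.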

Compound 4, half-maximal inhibitory concentration: 44000 nM
For compound 4 the middle estimate is 1.1-fold (0.06 log units) above the measured one, within the range that was stated.
By their numbers in this assay, from the lowest: compounds 3, 4, 2 and 1 (each within the scatter of the next).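

In this assay, among the compounds shown here, the exchange of 3-methoxyphenyl for 4-methoxyphenyl on a double-bonded chain carbon bound to a double-bonded ring carbon gives a 1.3-fold lower number from compound 2 to compound 4 (0.10 log units; within the scatter); this is the first direct reading of two compounds with the same atoms joined differently, and it shows that this rearrangement of the methoxyphenyl group does not separate compound 2 from compound 4. The exchange of pyridin-4-yl for 4-methoxyphenyl at the same place gives a 1.6-fold lower number from compound 1 to compound 4 (0.21 log units; within the scatter), so this second group exchange at the position also fails to produce a difference beyond the scatter. Nothing measured here offers an explanation for these results.

The compounds shown leave open whether any group at this place can move the number beyond the scatter, for example a phenyl ring carrying an amine, or a longer chain standing in place of the ring. They also leave open whether the same exchanges would read the same way with an amine in place of the carboxylic acid on the other side of the shared core.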